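The source may report more compounds than this note shows. Statements on the series, on what has been measured and on what is new or still open speak of the compounds shown alone.

Measured so far: compound 1 `Nc1cc(N)c2nc(-c3ccccc3)c(NCc3ccc(Cl)c(Cl)c3)nc2c1` with < 100000 nM in a functional assay on RXF 393 cells (Homo sapiens) for inhibition, read by sulforhodamine B assay, with a stated time of 48 h; a lower number here means that less compound is tolerated, a higher number that more compound is tolerated; compound 2 `COc1ccc(CNc2nc3cc(N)cc(N)c3nc2-c2ccccc2)cc1OC` with < 100000 nM in this assay.

Both numbers are limits of the assay, not measured values. Compound 1 reaches only a limit in this assay. Compound 2 likewise reaches only a limit in this assay, so compound 2 cannot be placed against compound 1 beyond saying that both sit at the limit of < 100000 nM in this assay, at which 2 of the 2 values shown sit. Among the compounds with values here, the one change between them, a step that the two limits leave unreadable from compound 1 to compound 2, is therefore unreadable in size and direction.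

Compound 3 `COc1cc(CNc2nc3cc(N)cc(N)c3nc2-c2ccccc2)cc(OC)c1OC` differs from compound 2 by methoxy in place of hydrogen on an aromatic carbon. Within the data shown here, no measured step bears on this change; the only step in hand, a step that the two limits leave unreadable from compound 1 to compound 2, gives no reading. The expected step that the limit leaves unreadable from compound 2 to compound 3 is therefore set at none beyond the scatter, with wide uncertainty. Compound 3 is estimated at 30000 nM, in the range 5000 nM to 100000 nM.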

Compound 3, concentration lethal to 50% of the cells: < 50200 nM
Compound 3: only a limit was reported; the forecaster's own chance of this, stated with the estimate: 45%; the middle value is on the limit's open side.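

In this assay, within the data shown here, compound 3 reaches only the limit < 50200 nM and compound 2 also stands at a limit, so no step between compound 2 and compound 3 can be read. Still open, going by these compounds, are the actual levels of compounds 1, 2 and 3 in this assay and whether methoxy in place of hydrogen on an aromatic carbon shifts them at all.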